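Dithiocarbamate-linked benzamides: antiproliferative read-out and one open case

This account rests on a few compounds, and the source may have more. Where it says the series, first, only, none or still open, it means among the compounds named here.

Measured so far in a functional assay on HeLa cells (Homo sapiens) for antiproliferative activity, read by CCK-8 assay, with a stated time of 72 h, tested at 8 uM; on this read-out higher numbers stand for a stronger effect at the one concentration tested and lower numbers for a weaker effect:
compound 1 `Nc1ccccc1NC(=O)c1ccc(CSC(=S)N2CCN(C(c3ccccc3)c3ccccc3)CC2)cc1`, giving 13.8%
compound 2 `Nc1ccccc1NC(=O)c1ccc(CSC(=S)N2CCN(c3ccc(Cl)cc3)CC2)cc1`, giving 44.8%
compound 3 `CN(C(=S)SCc1ccc(C(=O)Nc2ccccc2N)cc1)c1cccnc1`, giving 70.5%

Compound 3 stands highest of the three numbers in this assay. Its nearest neighbour on the numbers is compound 2, which sits lower by a gap beyond the scatter; compound 1 sits furthest, also beyond the scatter. Among the compounds with values here, no pair among the three differs in one place only, so no single step is isolated, and the three values are simply noted side by side.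

Compound 4 `CCN(Cc1ccncc1)C(=S)SCc1ccc(C(=O)Nc2ccccc2N)cc1` has not yet been measured in this assay. It differs from compound 3 in one place: ethyl((pyridin-4-yl)methyl)amino in place of methyl(pyridin-3-yl)amino on a thiocarbonyl carbon. The remaining part of the molecule is unchanged.

Within the data shown here, with no measured step to lean on, the size of this change is open. The two lower compounds carry other amines on the same thiocarbonyl carbon, so a step downward from compound 3 is the more likely direction, though a value within the scatter would not surprise. The estimate for compound 4 in this assay is 55%, within 30% to 78%. The step this estimate implies, a number 15.5 percentage points lower from compound 3 to compound 4 (beyond the scatter), is expected to be a modest decrease.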

Compound 4, a percentage reported as inhibition, at one concentration (the size of the read-out at that concentration, not a potency): 77.7%
Beside the measured number, compound 4's estimate is 22.7 percentage points below it; low and high end bracket the measured number.
By their numbers in this assay, from the lowest: compound 1; then compound 2; then compounds 3 and 4 (each within the scatter of the next).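

In this assay the series gains its first single-place step, a number 7.2 percentage points higher from compound 3 to compound 4 (within the scatter) on replacing methyl(pyridin-3-yl)amino with ethyl((pyridin-4-yl)methyl)amino on a thiocarbonyl carbon. At this position, the entering group has 10 heavy atoms against 8 for the leaving one, and the read-out stays within the scatter, so these two amines cannot be separated at the one concentration tested. Nothing available explains why the read-out holds at this position.

This single step combines the ethyl for methyl exchange, the added methylene link and the shift from pyridin-3-yl to pyridin-4-yl, so their separate contributions remain unresolved. Also open, from the compounds shown here alone, is whether an amine with no aromatic ring, such as diethylamino or morpholine, on the same thiocarbonyl carbon would keep the read-out in this range.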